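Compound 3: a furan in place of the 4-methoxyphenyl

The source may hold more compounds than are shown below. What is called first, only, known or untested is meant among the compounds shown, and "the series" means these compounds.

Values so far in a functional assay on LN-229 cells (Homo sapiens) for antiproliferative activity, with a stated time of 72 h; on this read-out lower numbers stand for stronger inhibition and higher numbers for weaker inhibition
- compound 1 (`Nc1ncnn2c([C@@H]3O[C@H](CO)[C@@H](O)[C@H]3O)cc(C#Cc3ccccc3)c12`) gives 88000 nM
- compound 2 (`COc1ccc(-c2cc([C@@H]3O[C@H](CO)[C@@H](O)[C@H]3O)n3ncnc(N)c23)cc1`) gives 40300 nM

Of the two measured compounds, compound 2 has the lower number (40300 nM), so it shows the stronger inhibition in this assay. Compound 3 (`Nc1ncnn2c([C@@H]3O[C@H](CO)[C@@H](O)[C@H]3O)cc(-c3ccoc3)c12`) has not yet been measured. It differs from compound 2 by one change (furan-3-yl in place of 4-methoxyphenyl on an aromatic carbon): furan-3-yl in place of 4-methoxyphenyl on an aromatic carbon, two ring bonds from the ring nitrogen.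

Among the compounds with values here, only one measured step bears on this change, and it concerns the same place on the shared core (a 2.2-fold lower number from compound 1 to compound 2 (0.34 log units; beyond the scatter)). That step is modest but beyond the scatter. Neither measured compound carries a furan, so this single step gives only weak guidance. A modest move towards a lower number is expected, though a larger move in either direction cannot be ruled out. The expected step is a 2.7-fold lower number from compound 2 to compound 3 (0.43 log units; beyond the scatter) in this estimate. For compound 3 the estimated value is 15000 nM, with an expected range from 1500 nM to 70000 nM.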

Compound 3, half-maximal inhibitory concentration: 1000 nM
Compound 3: middle estimate off by 15-fold (1.18 log units), on the high side; the measured number lies below the stated range.
By their numbers in this assay, from the lowest: compound 3; then compound 2; then compound 1.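

In this assay, the position on an aromatic carbon, two ring bonds from the ring nitrogen, turns out to tolerate far larger swings than had been visible: furan-3-yl in place of 4-methoxyphenyl gives a 40-fold lower number from compound 2 to compound 3 (1.61 log units; beyond the scatter) and furan-3-yl in place of 2-phenylethynyl gives an 88-fold lower number from compound 1 to compound 3 (1.94 log units; beyond the scatter) on the shared core. Both steps are much larger than the modest 2.2-fold lower number from compound 1 to compound 2 (0.34 log units; beyond the scatter) seen between the two earlier groups, so the group at this position can matter far more than that first step showed. The change from 4-methoxyphenyl to furan-3-yl alters several things at once, going from 8 heavy atoms to 5 and from a six-membered aromatic ring of carbon only to a five-membered aromatic ring with 1 hetero atom, and this single step does not separate these differences.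

A thiophene-3-yl, furan-2-yl or unsubstituted phenyl group at this position would be needed to tell whether the ring oxygen, its location or the smaller ring goes with the lower number. No measurement available here accounts for the size of this step.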